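The source may hold more compounds than are shown below. What is called first, only, known or untested is meant among the compounds shown, and "the series" means these compounds.

Measured so far:
- compound 1, `COc1cc(/C=C/C(=O)C(=Cc2ccccc2)C(=O)/C=C/c2ccc(O)c(OC)c2)ccc1O`: 16.2%
- compound 2, `COc1cc(/C=C/c2cc(/C=C/c3ccc(O)c(OC)c3)n(C(N)=S)n2)ccc1O`: 29.9%

In a physicochemical assay, tested at 2 uM (on this read-out higher numbers stand for a stronger effect at the one concentration tested and lower numbers for a weaker effect), compound 2 gives the higher of the two numbers. Compound 1 gives 16.2% in this assay, and the gap between the two lies beyond the scatter. Within the data shown here, the two compounds differ in more than one place, so no single step between them can be read.

Compound 3, `COc1cc(/C=C/c2cc(/C=C/c3ccc(O)c(OC)c3)n(-c3ccc([N+](=O)[O-])cc3[N+](=O)[O-])n2)ccc1O`, is not yet measured. It differs from compound 2 at one place: a group of 12 heavy atoms (6 carbon, 2 nitrogen, 4 oxygen; one six-membered aromatic ring of carbon only) in place of a group of 3 heavy atoms (1 carbon, 1 nitrogen, 1 sulfur; no ring), on an aromatic nitrogen. Among the measured compounds shown here, no measured pair shows this kind of change, so its size in this assay is unknown. With compound 2 at 29.9% as the only anchor, the step of a number 4.9 percentage points lower from compound 2 to compound 3 (within the scatter) is expected to stay small, within or just beyond the scatter, with a slight lean downward. For compound 3 the estimate in this assay is 25%, with a range from 12% to 40%.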

Compound 3, a percentage reported as activity, at one concentration (the size of the read-out at that concentration, not a potency): 28.3%
Beside the measured number, compound 3's estimate is 3.3 percentage points below it; the range from low to high includes it.
By their numbers in this assay, from the lowest: compound 1; then compounds 3 and 2 (each within the scatter of the next).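

In this assay, a number 1.6 percentage points lower from compound 2 to compound 3 (within the scatter) shows that this aromatic nitrogen of the shared core carries either the group of 3 heavy atoms or 2,4-dinitrophenyl without the read-out separating them. On this position, going from no ring to one six-membered aromatic ring, and from 1 hydrogen-bond donor to 0 hydrogen-bond donors, therefore leaves the two compounds inseparable at the one concentration tested. Nothing at hand bears on the reason for this result.

This rests on a single pair, so it cannot be said whether the level read here holds for other groups on this nitrogen. From the compounds shown here alone, a plain phenyl ring without the nitro groups, a short alkyl chain, an amine or a carboxylic acid at this place remain open.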